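This account rests on a few compounds, and the source may have more. Where it says the series, first, only, none or still open, it means among the compounds named here.

Measured so far:
- compound 1 `CC(C)(C)Cc1c(-c2ccoc2)sc(N)c1C(=O)c1ccc(Cl)cc1`: 1%
- compound 2 `CC(C)(C)Cc1c(-c2ccccn2)sc(N)c1C(=O)c1ccc(Cl)cc1`: 1%
- compound 3 `CC(C)(C)Cc1c(-c2ccc(F)cc2)sc(N)c1C(=O)c1ccc(Cl)cc1`: 9%

In an assay on CHO cells for displacement of a labelled ligand from adenosine receptor A3 (Homo sapiens), read by scintillation counting, tested at 10 uM (on this read-out lower numbers stand for less inhibition and higher numbers for more inhibition at the one concentration tested (going by the name of the read-out)), compound 3 gives 9%, the highest of the three numbers, though both of its neighbours lie within the scatter: the step of a number 8 percentage points higher from compound 1 to compound 3 (within the scatter) and the step of a number 8 percentage points higher from compound 2 to compound 3 (within the scatter) are each small. Compound 4 `CC(C)(C)Cc1c(-c2cccc(F)c2F)sc(N)c1C(=O)c1ccc(Cl)cc1` differs from compound 3 in one place: 2,3-difluorophenyl in place of 4-fluorophenyl on an aromatic carbon. Among the compounds with values here, no measured step exchanges one fluorinated phenyl for another, so the only bearing comes from the two steps into compound 3 above, both within the scatter and all three values near the floor of this assay. Compound 4 is therefore expected to show a number 2 percentage points lower from compound 3 to compound 4 (within the scatter), nothing beyond the scatter. The estimate for compound 4 is 7%, with a range of 0% to 18%.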

Compound 4, a percentage reported as inhibition, at one concentration (the size of the read-out at that concentration, not a potency): 1%
The estimate for compound 4 lay 6 percentage points above the measured number, and the stated range covers the measured number.
By their numbers in this assay, from the lowest: compounds 1, 2, 4 and 3 (each within the scatter of the next).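

Within the data shown here, with 2,3-difluorophenyl on the aromatic carbon next to the ring sulfur, the first exchange of one fluorinated phenyl for another gives a number 8 percentage points lower from compound 3 to compound 4 (within the scatter) in this assay and so does not separate the two groups. The comparisons with the other groups read the same way, no change at the digits printed from compound 2 to compound 4 (within the scatter) and no change at the digits printed from compound 1 to compound 4 (within the scatter) both leaving all four groups at this position within the scatter of one another. No measured evidence accounts for these numbers.

From the compounds shown here alone, whether a carboxylic acid or a primary amine at this position would move the number beyond the scatter remains open. The compounds shown also leave open what a longer chain in place of the neopentyl group would do.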